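A few compounds are considered here, and "the series" means these few. Any claim that something is new, unique, unknown or untested is made for them only; others in the source may bear on it.

Compound 1 `CCOC(=O)c1c(-c2cccc(OCC)c2)[nH]c2cc(OC)ccc2c1=O`, compound 2 `CCCOc1cccc(-c2[nH]c3cc(OC)ccc3c(=O)c2C(=O)OCC)c1` and compound 3 `CCOC(=O)c1c(-c2cccc(Oc3ccccc3)c2)[nH]c2cc(OC)ccc2c1=O` share one core and differ only in the group carried on an oxygen on an aromatic ring. In an ADME assay on HEK293 cells (Homo sapiens) for cytotoxicity, read by luminescence, with a stated time of 72 h (on this read-out higher numbers stand for an effect only at larger amounts of compound and lower numbers for an effect already at smaller amounts), compound 1 gives > 22000 nM, which is a limit of the assay and not a number. Compound 2 gives > 22000 nM in this assay, again only a limit. Compound 3 gives > 22000 nM in this assay, also a limit. Because of the limit of > 22000 nM in this assay, at which 3 of the 3 values shown sit, the steps a step that the two limits leave unreadable from compound 1 to compound 2, a step that the two limits leave unreadable from compound 1 to compound 3 and a step that the two limits leave unreadable from compound 2 to compound 3 cannot be sized, and compound 2 stands exactly where the other two stand, at that limit. Compound 4 `CCOC(=O)c1c(-c2cccc([N+](=O)[O-])c2)[nH]c2cc(OC)ccc2c1=O` has not yet been measured; it differs from compound 2 by nitro in place of propoxy on an aromatic carbon. Among the measured compounds shown here, the two steps that start from compound 2, a step that the two limits leave unreadable from compound 1 to compound 2 and a step that the two limits leave unreadable from compound 2 to compound 3, bear on this change but carry no readable size, and no measured pair shows nitro in place of propoxy. For the measured compounds named here, the expected step is therefore a step that the limit leaves unreadable from compound 2 to compound 4, which is no step that the measurements can resolve. Compound 4 is expected to give about 30000 nM, within a range from 10000 nM to 100000 nM.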

Compound 4, half-maximal effective concentration: > 22000 nM
Compound 4: no number, only a limit; the forecaster's own chance of this, stated with the estimate: 70%; the middle value does not contradict the limit.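

Among the compounds shown here, no step from compound 1, compound 2 or compound 3 to compound 4 can be read, because all four compounds stop at the same limit and give no number: the limit of > 22000 nM in this assay, at which 4 of the 4 values shown sit. The compounds shown leave open whether ethoxy, propoxy, phenoxy and nitro differ at all in their effect on these cells.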